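Compound 1 to compound 3: swapping the nitrogen substituent

A few compounds are considered here, and "the series" means these few. Any claim that something is new, unique, unknown or untested is made for them only; others in the source may bear on it.

Among the compounds with values here, in a functional assay on MDA-MB-435 cells (Homo sapiens) for cytotoxicity, read by MTT assay, with a stated time of 72 h (on this read-out higher numbers stand for weaker inhibition and lower numbers for stronger inhibition), compound 1 (`Nc1cccc(Nc2c(C(=O)NCc3ccc(F)cc3)nc(Br)c3cccnc23)c1`) gives 8000 nM and compound 2 (`N[C@H]1CC[C@H](NC(=O)c2nc(Br)c3cccnc3c2NCc2ccc(F)cc2)CC1`) gives 6600 nM on the only two numbers so far. These two values lie within the scatter of each other, so compound 1 stands level with compound 2 and neither ranks above the other.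

Within the data shown here, compound 3 (`C[C@H](Nc1c(C(=O)NCc2ccc(F)cc2)nc(Br)c2cccnc12)c1ccccc1`) has no measurement yet. It carries 1-phenylethyl in place of 3-aminophenyl on a nitrogen on an aromatic ring, and cut one bond further out the same change reads (3-aminophenyl)amino to (1-phenylethyl)amino. Compound 3 also has one defined stereocentre in the entering group.

Among the measured compounds shown here, no measured pair differs in one place, so this change has no direct precedent in this assay and its direction stays open. The expectation rests on compound 1 at 8000 nM and compound 2 at 6600 nM and is for no step beyond the scatter. The estimate of a 1.3-fold lower number from compound 1 to compound 3 (0.12 log units; within the scatter) is expected to stay within that scatter. For compound 3 an expected 6000 nM with a range of 2000 nM to 18000 nM is estimated.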

Compound 3, half-maximal inhibitory concentration: > 20000 nM
Compound 3 was reported as a limit; the forecaster's own chance of this, stated with the estimate: 10%; at least 3.3-fold (0.52 log units) between middle value and limit.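

1-phenylethyl in place of 3-aminophenyl on a nitrogen on an aromatic ring gives, in this assay, an at least 2.5-fold higher number from compound 1 to compound 3 (0.39 log units; beyond the scatter), the first step in the series that can be read at this place, and it shows that this nitrogen substituent is not indifferent to the change. Both groups carry a six-membered aromatic ring of carbon only, so such a ring on this nitrogen is not enough by itself to keep the level of compound 1. Compound 3 stands at > 20000 nM, which is a limit and not a number, so the step gives only a lower bound on the change: the limit of > 20000 nM in this assay, at which 1 of the 3 values shown sits.

Within the data shown here, the single step cannot tell apart the parts of the change: the amino group that leaves, the extra carbon atoms that enter and the defined stereocentre. Plain phenyl, benzyl or 3-hydroxyphenyl on the same nitrogen, and the other enantiomer of 1-phenylethyl, would each separate one of these parts, and how far the read-out moves with any of them remains open.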